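The compounds below may be only part of what the source reports. "The series", "measured", "known", "first", "only" and "open" are said of these compounds alone.

Working notes on the series.

Compound 1 `COc1ccc(C(=O)Nc2cccc(-c3oc4cc(-c5ccc(F)cc5)ccc4c(=O)c3O)c2)cc1` and compound 2 `Cc1ccccc1C(=O)Nc1cccc(-c2oc3cc(-c4ccc(F)cc4)ccc3c(=O)c2O)c1` share one core and differ only on the carbonyl carbon of the amide. In a functional assay on A549 cells (Homo sapiens) for antiproliferative activity, read by CCK-8 assay, with a stated time of 72 h (a lower number here means a stronger inhibitor, a higher number a weaker inhibitor), compound 1 gives 8700 nM, and in this assay compound 2 gives 17600 nM. Among the compounds with values here, the single step measured so far, a 2.0-fold higher number from compound 1 to compound 2 (0.31 log units; beyond the scatter), is the only guide for what follows. Within the data shown here, compound 2 thus stands at the weaker end of the two numbers known, with compound 1 as its only neighbour.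

Compound 3 `O=C(Nc1cccc(-c2oc3cc(-c4ccc(F)cc4)ccc3c(=O)c2O)c1)c1cc(F)cc(F)c1` is the next member. Relative to compound 2 the change is 3,5-difluorophenyl in place of 2-methylphenyl on a carbonyl carbon. Among the measured compounds shown here, no measured step covers a 3,5-difluorophenyl at this position; the step of a 2.0-fold higher number from compound 1 to compound 2 (0.31 log units; beyond the scatter) shows only that a swap of the aryl group on the carbonyl carbon can move this assay by a modest amount in either direction. The expected step is therefore small and uncertain, a 1.5-fold lower number from compound 2 to compound 3 (0.17 log units; within the scatter), estimated near the middle of the two measured values. Compound 3 is estimated at 12000 nM in this assay, with a likely range from 5000 nM to 30000 nM.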

Compound 3, half-maximal inhibitory concentration: 7620 nM
The estimate for compound 3 lay 1.6-fold (0.20 log units) above the measured number; measured number inside the range.
By their numbers in this assay, from the lowest: compounds 3 and 1 (each within the scatter of the next); then compound 2.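

In this assay, 3,5-difluorophenyl in place of 2-methylphenyl on the carbonyl carbon gives a 2.3-fold lower number from compound 2 to compound 3 (0.36 log units; beyond the scatter), so compound 2 now stands alone at the weak end of the series. In place of 4-methoxyphenyl, the same group gives a 1.1-fold lower number from compound 1 to compound 3 (0.06 log units; within the scatter), so two differently substituted aryl groups cannot be told apart at this position in this assay. No measurement at hand bears on why 2-methylphenyl stands apart from these two.

All three groups on the carbonyl carbon are aryl rings, which leaves open how a cyclohexyl ring, a longer alkyl chain or an aryl ring carrying an amine would read here. Also open, from the compounds shown here alone, is whether the higher number of compound 2 follows the methyl group itself or its place on the ring, a question that plain phenyl and 4-methylphenyl could help to settle.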